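The source may report more compounds than this note shows. Statements on the series, on what has been measured and on what is new or still open speak of the compounds shown alone.

Among the compounds with values here, compound 2 `COc1cccc2c1nnn2CC1CC1` is one of two compounds measured in a functional assay on cells for positive allosteric modulation of metabotropic glutamate receptor 2 (Homo sapiens), read by fluorescence and calcium flux, with a stated time of 30 min (on this read-out higher numbers stand for an effect only at larger amounts of compound and lower numbers for an effect already at smaller amounts), where compound 2 gives 400 nM. Within the data shown here, that is the highest of the two numbers; its nearest neighbour is compound 1 `Brc1cccc2c1nnn2CC1CC1`, which in this assay gives 70 nM, and the single known step, a 5.7-fold higher number from compound 1 to compound 2 (0.76 log units; beyond the scatter), is the only one available as a guide.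

Compound 3 `FC(F)(F)c1cccc2c1nnn2CC1CC1` is not yet measured. It differs from compound 2 in one place: trifluoromethyl in place of methoxy on an aromatic carbon. Among the measured compounds shown here, no measured pair shows this exact exchange, so the size of the step can only be bracketed. For the measured compounds named here, the one step on record, a 5.7-fold higher number from compound 1 to compound 2 (0.76 log units; beyond the scatter), shows that changing the group on this aromatic carbon moves the number by a modest but real amount, and that bromo sits lower than methoxy. A trifluoromethyl group is neither of these, and on the evidence of compound 1 and compound 2 alone the expectation for compound 3 is a number somewhere between the two, with a step of about a 2.7-fold lower number from compound 2 to compound 3 (0.43 log units; beyond the scatter) expected, toward a lower value. The estimate for compound 3 in this assay is therefore 150 nM, within a range from 40 nM to 600 nM.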

Compound 3, half-maximal effective concentration: 148 nM
Beside the measured number, compound 3's estimate is 1.0-fold (0.01 log units) above it; low and high end bracket the measured number.
By their numbers in this assay, from the lowest: compound 1; then compound 3; then compound 2.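

In this assay, the aromatic carbon now carries a third group, and trifluoromethyl falls at a level of its own: it lowers the number in place of methoxy (a 2.7-fold lower number from compound 2 to compound 3 (0.43 log units; beyond the scatter)) and raises it in place of bromo (a 2.1-fold higher number from compound 1 to compound 3 (0.33 log units; beyond the scatter)). Both steps lie beyond the scatter, so the three groups form an order rather than two levels, with bromo lowest, trifluoromethyl in the middle and methoxy highest. No measurement at hand accounts for this order, and the three values alone describe it without explaining it.

The compounds shown leave open whether an amine, a nitrile, a chloro group or a longer alkyl chain on the same aromatic carbon would fall inside the span set by bromo and methoxy or outside it. From the compounds shown here alone, the rest of the molecule is the same in all three compounds, so it also remains open whether this order of the three groups would hold if the shared core or its other substituent were changed.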